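Notes on pyridinyl replacements in a cytotoxicity series

The source may hold more compounds than are shown below. What is called first, only, known or untested is meant among the compounds shown, and "the series" means these compounds.

compound 1 (`Cc1cnc(Nc2ccc(C#N)cc2)nc1Nc1c(F)cc(-c2ccoc2)cc1F`): 4200 nM
compound 2 (`Cc1cnc(Nc2ccc(C#N)cc2)nc1Nc1c(F)cc(-c2ccnc(F)c2)cc1F`): 167000 nM
compound 3 (`Cc1cnc(Nc2ccc(C#N)cc2)nc1Nc1c(F)cc(-c2cc(F)nc(F)c2)cc1F`): 103000 nM

All three values come from a toxicity assay on MT4 cells (Homo sapiens) for cytotoxicity, read by MTT assay, with a stated time of 5 days (on this read-out higher numbers stand for lower toxicity in this test and lower numbers for higher toxicity in this test), and compound 3 sits at the high end of them, level with compound 2 within the scatter and well clear of compound 1. Replacing furan-3-yl with a fluorinated pyridinyl group gave two large steps: a 40-fold higher number from compound 1 to compound 2 (1.60 log units; beyond the scatter) and a 25-fold higher number from compound 1 to compound 3 (1.39 log units; beyond the scatter) in the same direction. Fluoro in place of hydrogen gave only a 1.6-fold lower number from compound 2 to compound 3 (0.21 log units; within the scatter) and so no real change.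

The next compound is compound 4 (`Cc1cnc(Nc2ccc(C#N)cc2)nc1Nc1c(F)cc(-c2cncc(C(F)(F)F)c2)cc1F`), which carries 5-(trifluoromethyl)pyridin-3-yl in place of 2,6-difluoropyridin-4-yl on an aromatic carbon. Among the measured compounds shown here, no measured step exchanges one pyridinyl group for another of this kind. The closest guide is the small step of a 1.6-fold lower number from compound 2 to compound 3 (0.21 log units; within the scatter) rather than the large steps away from furan-3-yl. The expected step is a 1.3-fold lower number from compound 3 to compound 4 (0.11 log units; within the scatter) in this assay with no change beyond the scatter anticipated. For compound 4 the estimate is 80000 nM with an expected range of 20000 nM to 220000 nM as its span.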

Compound 4, half-maximal cytotoxic concentration: 8200 nM
Compound 4: middle estimate off by 9.8-fold (0.99 log units), on the high side; the whole stated range lies above it.
By their numbers in this assay, from the lowest: compounds 1 and 4 (each within the scatter of the next); then compounds 3 and 2 (each within the scatter of the next).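

In this assay, the fluorinated pyridinyl groups at this position do not behave as a single class: 5-(trifluoromethyl)pyridin-3-yl departs sharply from both 2,6-difluoropyridin-4-yl (a 13-fold lower number from compound 3 to compound 4 (1.10 log units; beyond the scatter)) and 2-fluoropyridin-4-yl (a 20-fold lower number from compound 2 to compound 4 (1.31 log units; beyond the scatter)). Against furan-3-yl it shows no difference beyond the scatter (a 2.0-fold higher number from compound 1 to compound 4 (0.29 log units; within the scatter)), so compound 4 goes against any reading of the high numbers of compound 2 and compound 3 as a general feature of fluorinated pyridinyl groups here. No evidence at hand accounts for this split.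

The attachment point on the pyridine and the substituent both change in this step, so the compounds shown cannot separate the two. Plain pyridin-3-yl or 2-(trifluoromethyl)pyridin-4-yl would pull them apart, and how an amine or a carboxylic acid on the pyridine would read remains open.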